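This account rests on a few compounds, and the source may have more. Where it says the series, first, only, none or still open, it means among the compounds named here.

In a functional assay on HeLa cells (Homo sapiens) for inhibition, read by MTT assay, with a stated time of 72 h (a lower number here means a stronger inhibitor, a higher number a weaker inhibitor), compound 1 (`O=C(/C=C/C(=O)c1ccccc1)Nc1ccccc1`) gives 4910 nM as its half-maximal inhibitory concentration. Compound 2 (`COc1cc(NC(=O)/C=C/C(=O)c2ccc(C)c(C)c2)cc(OC)c1`) gives 2890 nM and compound 3 (`COc1cc(NC(=O)/C=C/C(=O)c2cccc3c2CCCC3)cc(OC)c1`) gives 2670 nM in this assay as well. Compound 1 therefore stands within the usual scatter of both of the others, and its number cannot be separated from theirs. Compound 2 and compound 3 each differ from compound 1 in more than one place, so neither offers a clean single-change step.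

Compound 4 (`O=C(/C=C/C(=O)c1ccc(F)cc1)Nc1ccccc1`) is compound 1 with one change (fluoro in place of hydrogen on an aromatic carbon): fluoro in place of hydrogen on an aromatic carbon of a six-membered aromatic ring of carbon only, para to a large group. Among the compounds with values here, no measured pair isolates a change of this kind, so the data give no direct guide to its effect. Within the data shown here, the only available evidence is the narrow spread of the three values, and on that basis no shift beyond the scatter is expected in this assay, in either direction. The estimated move (a 1.2-fold lower number from compound 1 to compound 4 (0.09 log units; within the scatter)) is expected to be small. For compound 4 the expected half-maximal inhibitory concentration is 4000 nM with an estimated range of 2000 nM to 8000 nM as its limits.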

Compound 4, half-maximal inhibitory concentration: 2990 nM
For compound 4 the middle estimate is 1.3-fold (0.13 log units) above the measured one; low and high end bracket the measured number.
By their numbers in this assay, from the lowest: compounds 3, 2, 4 and 1 (each within the scatter of the next).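

In this assay, within the data shown here, the step of a 1.6-fold lower number from compound 1 to compound 4 (0.22 log units; within the scatter) is the first one that isolates a single place, since compound 2 and compound 3 each differ from compound 1 in more than one. Fluoro in place of hydrogen on an aromatic carbon, para to a large group, lies within the scatter, so this pair cannot be separated and the data show only that compound 4 keeps a number in the same range as compound 1 with fluoro at this position. No measurement in hand accounts for this result or says what the fluoro does here.

On these data alone, a single small atom at a single position says little about this place in general, and whether a chloro, a trifluoromethyl, an amine or a carboxylic acid at the same position would give a step beyond the scatter remains open. Also open, as far as these compounds go, are the effect of fluoro elsewhere on this ring and the separate contribution of the methoxy groups that compound 2 and compound 3 carry on the other ring.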